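Chloro for Methoxy in an Inactive Thiourea Pair

This account rests on a few compounds, and the source may have more. Where it says the series, first, only, none or still open, it means among the compounds named here.

Compound 1: `COc1cccc(NC(=S)NCCNS(=O)(=O)c2ccc(-c3ccccc3Oc3ccc([N+](=O)[O-])cc3)s2)c1` — > 50000 nM
Compound 2: `O=[N+]([O-])c1cccc(NC(=S)NCCNS(=O)(=O)c2ccc(-c3ccccc3OCc3ccccc3)s2)c1` — > 50000 nM

The study uses a functional assay on HL-60 cells (Homo sapiens) for inhibition, read by CCK-8 assay, with a stated time of 48 h; a higher number here means a weaker inhibitor, a lower number a stronger inhibitor. Compound 1 `COc1cccc(NC(=S)NCCNS(=O)(=O)c2ccc(-c3ccccc3Oc3ccc([N+](=O)[O-])cc3)s2)c1` gives > 50000 nM, which is a limit of the assay rather than a number. Compound 2 `O=[N+]([O-])c1cccc(NC(=S)NCCNS(=O)(=O)c2ccc(-c3ccccc3OCc3ccccc3)s2)c1` gives > 50000 nM, which is likewise a limit. Going by the values given here, compound 1 therefore stands nowhere that can be ranked: both values shown rest on (the limit of > 50000 nM in this assay, at which 2 of the 2 values shown sit), and no step between measured compounds exists.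

Compound 3 `O=[N+]([O-])c1ccc(Oc2ccccc2-c2ccc(S(=O)(=O)NCCNC(=S)Nc3cccc(Cl)c3)s2)cc1` is to be measured in this assay. It differs from compound 1 by chloro in place of methoxy on an aromatic carbon. With compound 1 sitting only at a limit, the step from compound 1 to compound 3 cannot be anchored to any measured change, and no movement beyond the scatter can be foreseen from the data. The expected step is a number no higher from compound 1 to compound 3 (the limit leaves the size open), which amounts to no change. Compound 3 is expected to give 50000 nM in this assay, within a range from 20000 nM to 200000 nM, and it is expected most likely to be reported as a limit again.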

Compound 3, half-maximal inhibitory concentration: > 50000 nM
Compound 3 gave a limit, no number; the forecaster's own chance of this, stated with the estimate: 85%; the middle value sits exactly at the limit.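

In this assay compound 3 gives > 50000 nM, which is a limit and not a number. The step from compound 1 to compound 3 therefore cannot be read: the limit of > 50000 nM in this assay, at which 3 of the 3 values shown sit.

The compounds shown leave open how strongly any of them inhibits, and whether chloro in place of methoxy makes any difference at all.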